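The source may hold more compounds than are shown below. What is called first, only, known or untested is meant among the compounds shown, and "the series" means these compounds.

Compounds measured in a physicochemical assay for permeability, using PAMPA; a higher number here means that the compound crosses the layer faster, a lower number that the compound crosses the layer more slowly:
- compound 1 `O=C(O)CCn1c(=O)oc2cc(OCc3ccccc3)c(Cl)cc21`: "not determined" (no result reported)
- compound 2 `CC(C)Cc1cc2oc(=O)n(CCC(=O)O)c2cc1Cl`: < 10 nm/s (a limit of the assay, not a number)
- compound 3 `O=C(O)CCn1c(=O)oc2cc(OCc3ccccn3)c(Cl)cc21`: 11 nm/s

Among the compounds with values here, compound 3 stands alone here as the only compound with an actual number. Compound 1 has no result to compare with it. Within the data shown here, compound 2 is the one compound at the limit of < 10 nm/s in this assay, at which 1 of the 3 values shown sits.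

The next compound is compound 4 `COc1cc2oc(=O)n(CCC(=O)O)c2cc1Cl`, which keeps the shared core and changes one group: hydrogen in place of pyridin-2-yl on a saturated chain carbon bound to an oxygen on an aromatic ring. In words, this is hydrogen in place of pyridin-2-yl on a saturated chain carbon bound to an oxygen on an aromatic ring, so (pyridin-2-yl)methoxy becomes methoxy.

Among the measured compounds shown here, only one measured step involves this group: an at least 1.1-fold higher number from compound 2 to compound 3 (0.04 log units; that floor lies within the scatter). There, (pyridin-2-yl)methoxy takes the place of isobutyl. One end of that step is a limit, so it gives a floor and not a true size, and it says little about a change to methoxy.

Resting on that step and on compound 3 at 11 nm/s, no step beyond the scatter is expected in this assay. For compound 4, a result reported only as a limit would be quite possible. The expected change is no change at the digits printed from compound 3 to compound 4 (within the scatter). For compound 4 the estimated value is 11 nm/s, with an expected range from 5 nm/s to 25 nm/s.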

Compound 4, apparent permeability: < 3 nm/s
Compound 4 was reported as a limit (the forecaster's own chance of this, stated with the estimate: 45%); middle value at least 3.6-fold (0.56 log units) from the limit.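

Cutting pyridin-2-yl back to hydrogen on a saturated chain carbon bound to an oxygen on an aromatic ring turns (pyridin-2-yl)methoxy into methoxy, and in this assay this gives an at least 3.6-fold lower number from compound 3 to compound 4 (0.56 log units; beyond the scatter). Within the data shown here, the only earlier step involving this group, an at least 1.1-fold higher number from compound 2 to compound 3 (0.04 log units; that floor lies within the scatter), had a floor that told nothing firm, so this is the first step involving this group that is printed as beyond the scatter. Its size is a floor and not a true size, since the result for compound 4 is a limit of the assay and not a number: the limit of < 3 nm/s in this assay, at which 1 of the 4 values shown sits.

The step that links methoxy with isobutyl cannot be read, as both of its ends are limits. Also open, going by these compounds, is where a group of intermediate size, such as ethoxy, or a longer chain ending in an amine would fall in this assay, and the entry for compound 1, "not determined" (no result reported), gives no number to set beside the others.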